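A Sulfonyl Swap on a Shared Core

This account rests on a few compounds, and the source may have more. Where it says the series, first, only, none or still open, it means among the compounds named here.

The series is followed in a functional assay on K562 cells (Homo sapiens) for inhibition, read by trypan blue exclusion, with a stated time of 72 h; a lower number here means a stronger inhibitor, a higher number a weaker inhibitor. Among the measured compounds shown here, compound 1, `Cn1c(=O)c(S(=O)(=O)Cc2ccc(F)cc2F)cc2cnc(Nc3ccc4[nH]ccc4c3)nc21`, gives 1000 nM in this assay, which places it second highest of the three numbers known so far. Compound 3, `O=c1c(S(=O)(=O)c2ccc(F)cc2F)cc2cnc(Nc3ccc4[nH]ccc4c3)nc2n1C1CC1`, gives 500 nM, and its number lies within the scatter of that of compound 1, so the two cannot be told apart. Compound 2, `Cn1c(=O)c(S(=O)(=O)c2ccc(Cl)cc2)cc2cnc(Nc3cnc4ccccc4c3)nc21`, gives 15000 nM, a number that stands well beyond the scatter from compound 1.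

Compound 4, `Cc1ccc(S(=O)(=O)c2cc3cnc(Nc4ccc5[nH]ccc5c4)nc3n(C)c2=O)cc1`, has not been measured. It differs from compound 1 at one place: 4-methylphenyl in place of 2,4-difluorobenzyl on a sulfonyl sulfur. For the measured compounds named here, no measured pair shows this exact change, so the size of the step is uncertain. The closest guide is that compound 3, which also carries a ring bound straight to the sulfonyl sulfur, gives 500 nM, a number close to that of compound 1.

Compound 4 is therefore expected to give about 1500 nM in this assay, within a range from 400 nM to 6000 nM. The estimated step of a 1.5-fold higher number from compound 1 to compound 4 (0.18 log units; within the scatter) is expected to stay within the scatter.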

Compound 4, half-maximal inhibitory concentration: 750 nM
Compound 4: middle estimate off by 2.0-fold (0.30 log units), on the high side; the measured number falls inside the stated range.
By their numbers in this assay, from the lowest: compounds 3, 4 and 1 (each within the scatter of the next); then compound 2.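

Among the compounds shown here, replacing 2,4-difluorobenzyl with 4-methylphenyl on a sulfonyl sulfur gives the first direct reading at this position: in this assay, the step (a 1.3-fold lower number from compound 1 to compound 4 (0.12 log units; within the scatter)) leaves compound 4 indistinguishable from compound 1. On the shared core, then, this one change can be made without a measurable shift in this assay, even though the entering group carries no fluorine and has fewer heavy atoms. No measurement shown here gives a reason for this result.

This single pair says nothing about how a group of a different kind would behave on the sulfonyl sulfur, such as a longer alkyl chain, a carboxylic acid or an amine. Compound 2 differs from compound 1 in more than one place, so the compounds shown do not reveal which change accompanies its much higher number.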